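The source may hold more compounds than are shown below. What is called first, only, known or untested is meant among the compounds shown, and "the series" means these compounds.

Measured so far in a functional assay on NIH3T3 cells (Mus musculus); on this read-out higher numbers stand for an effect only at larger amounts of compound and lower numbers for an effect already at smaller amounts:
- compound 1, `CSCC[C@H](NC(=O)c1ccc(CNCc2c[nH]cn2)cc1-c1ccccc1C)C(=O)O`: > 25 uM
- compound 2, `CSCC[C@H](NC(=O)c1ccc(NCc2cncn2Cc2cccc(C)c2)cc1-c1ccccc1)C(=O)O`: > 10 uM

Both entries are limits of this assay, not numbers. Compound 2 stands at the limit of > 10 uM in this assay, at which 1 of the 2 values shown sits, so its value in this assay is known only as a limit. Compound 1 stands at the limit of > 25 uM in this assay, at which 1 of the 2 values shown sits, likewise only a limit. For the measured compounds named here, the two values therefore show no more than that neither compound gave a half-maximal effect within its tested range, and no step between them can be read.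

The next compound is compound 3, `CSCC[C@H](NC(=O)c1ccc(NCc2cncn2Cc2cccc(Cl)c2)cc1-c1ccccc1)C(=O)O`. It differs from compound 2 by chloro in place of methyl on an aromatic carbon; in words, chloro in place of methyl on an aromatic carbon, meta to a large group.

Going by the values given here, with no measured step to lean on, the expectation for compound 3 rests on the limit of compound 2 alone. The step that the limit leaves unreadable from compound 2 to compound 3 is expected to be none beyond the scatter, in either direction. Compound 3 is therefore estimated at 20 uM, in a range from 8 uM to 60 uM, and a limit rather than a number is the more likely report.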

Compound 3, concentration for half-maximal effect: > 10 uM
Compound 3: a limit, no number; the forecaster's own chance of this, stated with the estimate: 75%; the middle value lies beyond the limit too.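

In this assay compound 2 and compound 3 both stand as limits, not numbers, so no step can be read for chloro in place of methyl on an aromatic carbon: the limit of > 10 uM in this assay, at which 2 of the 3 values shown sit.

The compounds shown leave open where the half-maximal concentration of any of them lies, and whether methyl or chloro at this place makes any difference in this assay.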